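This account rests on a few compounds, and the source may have more. Where it says the series, first, only, none or still open, it means among the compounds named here.

Compound 1 `O=S(=O)(c1ccccc1F)c1cn(C2CCNC2)c2ncccc12` is the reference point. In a functional assay on HeLa cells for antagonist activity at 5-hydroxytryptamine receptor 6 (Homo sapiens), read by cAMP accumulation and immunoassay (on this read-out higher numbers stand for weaker inhibition and lower numbers for stronger inhibition), compound 1 gives 50 nM, the lowest of the two numbers recorded so far. For the measured compounds named here, its nearest companion is compound 2 `CN1CCC(n2cc(S(=O)(=O)c3ccccc3F)c3cccnc32)C1`, which in this assay gives 186 nM; the only step recorded, a 3.7-fold higher number from compound 1 to compound 2 (0.57 log units; beyond the scatter), comes from a methyl in place of hydrogen on an amine nitrogen in a ring and is beyond the scatter.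

Compound 3 `O=S(=O)(Cc1ccc(Cl)s1)c1cn(C2CCNC2)c2ncccc12` keeps that ring amine unmethylated and instead alters the group on the sulfonyl sulfur: (5-chlorothiophen-2-yl)methyl in place of 2-fluorophenyl on a sulfonyl sulfur. Going by the values given here, no measured pair touches this place, so the step from compound 1 to compound 2 offers no direct guide, and the direction of the change is open. With the sulfonyl substituent of compound 1 untested elsewhere in these data, compound 3 is expected to land on the weaker side of compound 1, though the estimate carries a wide range.

Compound 3 is estimated in this assay at 180 nM, between 35 nM and 900 nM, which is expected to mean a step of a 3.6-fold higher number from compound 1 to compound 3 (0.56 log units; beyond the scatter).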

Compound 3, half-maximal inhibitory concentration: 11 nM
For compound 3 the middle estimate is 16-fold (1.21 log units) above the measured one, and the stated range ends above it.
By their numbers in this assay, from the lowest: compound 3; then compound 1; then compound 2.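

For the compounds shown here, the sulfonyl sulfur proves to be a place where the number in this assay can fall as well as rise: (5-chlorothiophen-2-yl)methyl in place of 2-fluorophenyl gives a 4.5-fold lower number from compound 1 to compound 3 (0.66 log units; beyond the scatter), whereas the only earlier change, at the ring amine nitrogen, moved the number upward. Both groups have 7 heavy atoms, so this step comes with a change in the kind and arrangement of the atoms rather than their number, and the aromatic ring of carbon only gives way to a five-membered aromatic ring with a hetero atom and a chlorine. No measurement shown here accounts for the step or assigns it to any one part of the new group.

Going by these compounds, it remains open whether methyl on the ring amine nitrogen would carry the same penalty with the new sulfonyl group as in a 3.7-fold higher number from compound 1 to compound 2 (0.57 log units; beyond the scatter). Also open, on these data alone, is which part of the (5-chlorothiophen-2-yl)methyl group matters, a question that a benzyl group, an unsubstituted thiophen-2-ylmethyl group or a bromine in place of the chlorine would each address.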